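Fluoro to cyano swap across two cores

A few compounds are considered here, and "the series" means these few. Any claim that something is new, unique, unknown or untested is made for them only; others in the source may bear on it.

Compound 1 `CC(O)(C(=O)Nc1ccc(S(=O)(=O)c2ccccc2F)cc1)C(F)(F)F` and compound 2 `CC(O)(C(=O)Nc1ccc(S(=O)(=O)c2ccccc2C#N)cc1)C(F)(F)F` share one core; the difference between them is cyano in place of fluoro on an aromatic carbon. In a functional assay (Cavia porcellus) with sulfonylurea receptors; K-ATP channels (Homo sapiens) as the target (a lower number here means a stronger inhibitor, a higher number a weaker inhibitor), compound 1 gives 1300 nM, and compound 2 gives 1100 nM; the step of a 1.2-fold lower number from compound 1 to compound 2 (0.07 log units; within the scatter) lies within the scatter, so the two numbers are read as equal. Compound 3 `CC(O)(C(=O)Nc1ccc(C(=O)c2ccccc2)cc1F)C(F)(F)F` is built on another core, and the difference between the two cores is not broken down here. In this assay compound 3 gives 11000 nM, the highest of the three numbers, beyond the scatter from both compound 1 and compound 2. Compound 4 `CC(O)(C(=O)Nc1ccc(C(=O)c2ccccc2)cc1C#N)C(F)(F)F` has not been measured yet. Its difference from compound 3 is cyano in place of fluoro on an aromatic carbon, the same kind of change as from compound 1 to compound 2 but not the same: the place in compound 4 is also meta to a benzoyl group, which the place in compound 2 is not. Because a 1.2-fold lower number from compound 1 to compound 2 (0.07 log units; within the scatter) lies within the scatter, the step of a 1.2-fold lower number from compound 3 to compound 4 (0.06 log units; within the scatter) is expected to be small as well. Compound 4 is therefore estimated at 9500 nM in this assay, between 4000 nM and 22000 nM.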

Compound 4, half-maximal inhibitory concentration: 3800 nM
Compound 4: middle estimate off by 2.5-fold (0.40 log units), on the high side, outside the stated range (below it).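

In this assay, cyano in place of fluoro on an aromatic carbon gives a 2.9-fold lower number from compound 3 to compound 4 (0.46 log units; beyond the scatter), a modest step beyond the scatter, while on the core of compound 1 the same change stays within the scatter. The two steps still cannot be told apart, so this series gives no evidence that the outcome depends on the core: the same change on two cores in this assay, a 1.2-fold lower number (0.07 log units; within the scatter) from compound 1 to compound 2 and a 2.9-fold lower number (0.46 log units; beyond the scatter) from compound 3 to compound 4, 2.4-fold (0.39 log units) apart, within the scatter of two such steps. For the compounds shown here, with only two pairs, this shows that the change raised the number beyond the scatter on neither core, but it does not show that the size of the step would carry over to a further core.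

Open, as far as these compounds go, is how an amine, a methoxy group or a carboxylic acid at the same place would compare with fluoro and cyano on either core. Also open, from the compounds shown here alone, is what separates the two cores themselves, as compound 1 and compound 3 differ in more than one place.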